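This account rests on a few compounds, and the source may have more. Where it says the series, first, only, none or still open, it means among the compounds named here.

Compound 1 `C=C1[C@H](C)CCC[C@]1(C)CC/C(C)=C/CC1=C(O)C(=O)C=C(N[C@@H](CO)C(=O)O)C1=O`, compound 2 `C=C1[C@H](C)CCC[C@]1(C)CC/C(C)=C/CC1=C(O)C(=O)C=C(N[C@@H](C(=O)O)C(C)C)C1=O` and compound 3 `COC1=CC(=O)C(O)=C(C/C=C(\C)CC[C@@]2(C)CCC=C(C)[C@H]2C)C1=O` share the same core and were tested for how strongly they harm cultured cells. In an ADME assay on KB cells (Homo sapiens) for cytotoxicity, with a stated time of 48 h (a lower number here means a stronger inhibitor, a higher number a weaker inhibitor), compound 1 reaches only the limit of the assay, > 10 ug/mL. Compound 3 likewise gives only a limit, > 10 ug/mL. Going by the values given here, compound 2 gives 6.2 ug/mL, the one outright number among the three, which places it at the more inhibitory end of what has been measured. Among the compounds with values here, the single measured step, an at least 1.6-fold lower number from compound 1 to compound 2 (0.20 log units; that floor lies within the scatter), has a floor that sits within the scatter, so it shows at most a modest gain on moving from the hydroxyl-bearing side chain to the methyl-bearing one.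

Compound 4 `C=C1[C@H](C)CCC[C@]1(C)CC/C(C)=C/CC1=C(O)C(=O)C=C(N[C@H](C(=O)O)[C@H](C)O)C1=O` differs from compound 2 by 1-carboxy-2-hydroxypropyl in place of 1-carboxy-2-methylpropyl on an amine nitrogen. This change runs in the opposite sense to the measured step, bringing a hydroxyl back into the side chain on the amine nitrogen, so the expectation is a number somewhat higher than that of compound 2, with a real chance that the result lands back at the limit because of the limit of > 10 ug/mL in this assay, at which 2 of the 3 values shown sit. Compound 4 is therefore expected to give 9 ug/mL, within 5 ug/mL to 16 ug/mL. The step of a 1.5-fold higher number from compound 2 to compound 4 (0.16 log units; within the scatter) is expected to be a small rise, barely beyond the scatter.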

Compound 4, half-maximal inhibitory concentration: > 10 ug/mL
Compound 4: only a limit was reported (the forecaster's own chance of this, stated with the estimate: 40%); middle value at least 1.1-fold (0.04 log units) from the limit.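

Compound 4 gives only a limit in this assay, > 10 ug/mL. As far as these compounds go, replacing 1-carboxy-2-methylpropyl with 1-carboxy-2-hydroxypropyl on the amine nitrogen gives an at least 1.6-fold higher number from compound 2 to compound 4 (0.20 log units; that floor lies within the scatter), so the drop in cell harm may be small or may not be real, and its true size remains unknown. Among the amine-linked compounds, the two whose side chains carry a hydroxyl, compound 1 and compound 4, now both stop at the limit, while compound 2, whose side chain has none, gives an outright number; compound 3 goes against any simple link to the hydroxyl, as it has no such side chain and still stops at the limit.

From the compounds shown here alone, how far compound 1 and compound 4 lie beyond that limit stays open, and the step between them cannot be read: the limit of > 10 ug/mL in this assay, at which 3 of the 4 values shown sit. Also open is whether an amine or a longer carbon chain in place of the hydroxyl or methyl end of this side chain would give a number clearly beyond the scatter from that of compound 2.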